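The source may hold more compounds than are shown below. What is called first, only, known or untested is meant among the compounds shown, and "the series" means these compounds.

Measured in a functional assay on MJ cells (Homo sapiens) for antiproliferative activity, with a stated time of 48 h; on this read-out higher numbers stand for weaker inhibition and lower numbers for stronger inhibition:
compound 1, `O=C1C=C[C@]2(C[C@@H](c3ccccc3)O[C@@H](c3cccc([N+](=O)[O-])c3)O2)O1`: 340 nM
compound 2, `O=C1C=C[C@]2(C[C@@H](c3c(F)c(F)c(F)c(F)c3F)O[C@@H](c3c(F)c(F)c(F)c(F)c3F)O2)O1`: 2000 nM
compound 3, `O=C1C=C[C@]2(C[C@@H](c3cccc(Cl)c3)O[C@@H](c3cccc(Cl)c3)O2)O1`: 260 nM

Compound 1 stands second highest of the three numbers. Its nearest neighbour is compound 3, whose value lies slightly lower but within the scatter, so the two cannot be told apart on this read-out. Compound 2 sits well beyond the scatter on the high side and is the clearly weaker inhibitor of the three.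

Compound 4, `O=C1C=C[C@]2(C[C@@H](c3cccc([N+](=O)[O-])c3)O[C@@H](c3cccc([N+](=O)[O-])c3)O2)O1`, has not yet been measured in this assay. It is derived from compound 1 by nitro in place of hydrogen on an aromatic carbon. Among the compounds with values here, no measured pair in the set isolates this change, so its size cannot be read directly from the data. What the set does show is that compound 1 and compound 3, each carrying a single substituent on the aryl rings, sit close together, while only compound 2 moves far. Compound 4 keeps the same pattern of one substituent per ring, so the expectation is that the step of a 1.0-fold higher number from compound 1 to compound 4 (0.01 log units; within the scatter) is small, in no firm direction, and most likely within the scatter. Compound 4 is therefore expected to come in near 350 nM, with a plausible range from 150 nM to 900 nM.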

Compound 4, half-maximal inhibitory concentration: 170 nM
Beside the measured number, compound 4's estimate is 2.1-fold (0.31 log units) above it; low and high end bracket the measured number.
By their numbers in this assay, from the lowest: compounds 4, 3 and 1 (each within the scatter of the next); then compound 2.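

Within the data shown here, replacing the phenyl of compound 1 with 3-nitrophenyl, with the nitro group meta to a large group, gives in this assay a 2.0-fold lower number from compound 1 to compound 4 (0.30 log units; within the scatter), the first direct reading of a single change. At this position, the nitro group in place of hydrogen therefore leaves the antiproliferative read-out within the usual scatter, so this one pair shows that the added group is accommodated but establishes no gain in inhibition. Nothing available explains the size of this step or links it to any property of the nitro group.

Going by these compounds, whether this tolerance extends to other groups remains open, since a single pair cannot show how an amine, a carboxylic acid or a methoxy group at the same place on the ring would compare with nitro or hydrogen. Also open, on these data alone, is how a single change on the other aryl ring would read, for example a phenyl there in place of the 3-nitrophenyl of compound 1, with the rest of the core held constant.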